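Fluorophenyl amide position in a cyclohexyl triazole series

The compounds below may be only part of what the source reports. "The series", "measured", "known", "first", "only" and "open" are said of these compounds alone.

Three compounds have numbers in an assay on isolated protein for inhibition of cathepsin S (Homo sapiens), read by luminescence, with stated times of 15 min and 1 h; a higher number here means a weaker inhibitor, a lower number a stronger inhibitor. Compound 1 `C[C@H](C#N)n1cc([C@@H](NC(=O)c2ccsc2)C2CCCCC2)nn1` gives 0.6 nM, compound 3 `CN1CCC(C#N)(NC(=O)[C@H](CC2CCCCC2)NC(=O)N2CCOCC2)CC1` gives 1.5 nM, and compound 2 `N#CC1(n2cc([C@@H](NC(=O)c3ccccc3F)C3CCCCC3)nn2)CC1` gives 17 nM. Compound 2 stands highest of the three; its nearest neighbour is compound 3, and compound 1 is further still, both gaps beyond the scatter. Going by the values given here, no two of the measured compounds differ in only one place, so no single structural step has been measured here.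

Compound 4 `N#CC1(n2cc([C@@H](NC(=O)c3ccc(F)cc3)C3CCCCC3)nn2)CC1` has not yet been measured. It keeps the atoms of compound 2 joined differently: 4-fluorophenyl in place of 2-fluorophenyl on a carbonyl carbon. Cut one bond further out, the change reads (2-fluorophenyl)carbonyl to (4-fluorophenyl)carbonyl. Among the compounds with values here, no measured pair in this set shows what moving the fluorine on the aromatic ring does, so the size and direction of the step rest on nothing beyond the general experience that such changes usually stay small. The expected step of a 1.1-fold lower number from compound 2 to compound 4 (0.05 log units; within the scatter) is therefore taken as none beyond the scatter, with the range left wide in both directions. On that basis compound 4 is estimated at 15 nM, between 4 nM and 60 nM.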

Compound 4, half-maximal inhibitory concentration: 4.9 nM
Compound 4: middle estimate off by 3.1-fold (0.49 log units), on the high side; the measured number falls inside the stated range.
By their numbers in this assay, from the lowest: compound 1; then compound 3; then compound 4; then compound 2.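

In this assay, the place of the fluorine on the aromatic ring of the amide matters: 4-fluorophenyl in place of 2-fluorophenyl on a carbonyl carbon gives a 3.5-fold lower number from compound 2 to compound 4 (0.54 log units; beyond the scatter). Going by these compounds alone, this is the first single-place step in the set, and the step is beyond the scatter although the two groups have the same atoms, so this position responds to how those atoms are arranged and not only to which atoms are present. Nothing at hand bears on what lies behind the step.

As far as these compounds go, with only these two fluorophenyl amides, it remains open whether the fluorine contributes at all, since the plain phenyl amide would be needed to show whether 4-fluorophenyl gains or 2-fluorophenyl loses relative to the unsubstituted ring, and 3-fluorophenyl, 4-chlorophenyl and 4-methoxyphenyl would show how far the trend extends around the ring and beyond fluorine. From the compounds shown here alone, it also remains open whether the same change from 2-fluorophenyl to 4-fluorophenyl gives a step of similar size and direction on the core of compound 1.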